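The compounds below may be only part of what the source reports. "The series", "measured", "known", "first", "only" and "open" are said of these compounds alone.

Compound 2 `O=C1COc2ccc(-c3ccc(O)cc3)cc2N1`: > 40000 nM
Compound 1 `COc1ccc(N2C(=O)COc3ccc(-c4cnc5ccccc5c4)cc32)cc1`: > 40000 nM
Compound 3 `COc1ncc(-c2ccc3c(c2)N(c2ccc(F)cc2)C(=O)CO3)cc1NS(=O)(=O)c1ccc(F)cc1`: > 40000 nM

All three results come from a functional assay on A-375 cells (Homo sapiens) for antiproliferative activity, read by MTT assay, with a stated time of 72 h; a lower number here means a stronger inhibitor, a higher number a weaker inhibitor. The value for compound 2 is a limit of the assay, not a number. The value for compound 1 is likewise only a limit. The value for compound 3 is also only a limit. Every value shown sits at the same place (the limit of > 40000 nM in this assay, at which 3 of the 3 values shown sit), so compound 2 cannot be placed above or below the other two; the numbers show only that none of the three reached a measurable potency.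

The piece now turns to compound 4 `COc1cccc(N2C(=O)COc3ccc(-c4ccc(O)cc4)cc32)c1`, which differs from compound 2 in one place (3-methoxyphenyl in place of hydrogen on an amide-type nitrogen in a ring). Going by the values given here, no step between measured compounds exists that could give this change a size or a direction. Given that compound 2 gives > 40000 nM, no movement beyond the scatter is expected in this assay; the most likely outcome is that compound 4 again reports a limit. Compound 4 is therefore estimated at 40000 nM, between 8000 nM and 200000 nM. This estimate means an expected step of a number no higher from compound 2 to compound 4 (the limit leaves the size open), which is none beyond the scatter.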

Compound 4, half-maximal inhibitory concentration: 30400 nM
For compound 4 the middle estimate is 1.3-fold (0.12 log units) above the measured one; the measured number falls inside the stated range.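

In this assay, compound 4 is the only one of the four shown that gives a number and not a limit, so a measurable value can be read with 3-methoxyphenyl on this amide-type nitrogen in a ring. Placing that group on the nitrogen in place of hydrogen gives an at least 1.3-fold lower number from compound 2 to compound 4 (0.11 log units; that floor lies within the scatter). The real size of this step stays open, because compound 2 reports only a limit: the limit of > 40000 nM in this assay, at which 3 of the 4 values shown sit.

The compounds shown leave open whether this change moves the number beyond the scatter, and whether the methoxy group matters or a bare phenyl would read the same. They also leave open how an amine, a carboxylic acid or a longer alkyl chain would read on this nitrogen in this assay.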